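Compound 3: 4-methoxyphenyl in place of 2-chlorophenyl

The compounds below may be only part of what the source reports. "The series", "measured", "known", "first", "only" and "open" are said of these compounds alone.

In a functional assay on U-251 cells (Homo sapiens) for inhibition, read by MTT assay, with a stated time of 2 days (a lower number here means a stronger inhibitor of growth, a higher number a weaker inhibitor of growth), compound 2 `Nc1ccccc1NC(=O)CCCNCC(=O)Nc1ccccc1Cl` stands at > 100000 nM which is a limit of the assay and not a number. Compound 1 `Nc1ccccc1NC(=O)CCCNCC(=O)Nc1cccc([N+](=O)[O-])c1` gives 93500 nM as its measured value. Among the measured compounds shown here, the one measured step, an at least 1.0-fold higher number from compound 1 to compound 2 (0.02 log units; that floor lies within the scatter) stays within the scatter at its floor. Compound 3 `COc1ccc(NC(=O)CNCCCC(=O)Nc2ccccc2N)cc1` carries the change 4-methoxyphenyl in place of 2-chlorophenyl on an amide-type nitrogen on that same amide-type nitrogen. For the measured compounds named here, with only that step to go on, the expected step is an at least 1.1-fold lower number from compound 2 to compound 3 (0.04 log units; that floor lies within the scatter) which means none beyond the scatter. For compound 3 the estimate is 90000 nM with an expected range of 40000 nM to 100000 nM in this read-out.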

Compound 3, concentration for total growth inhibition: > 100000 nM
Compound 3 ended at the assay's limit; the forecaster's own chance of this, stated with the estimate: 50%; at least 1.1-fold (0.04 log units) between middle value and limit.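

In this assay compound 3 gives > 100000 nM as a limit of the assay and not a number. On this amide-type nitrogen, 4-methoxyphenyl therefore ends at the same limit as 2-chlorophenyl, so a second, differently substituted phenyl group gives no measurable value: the limit of > 100000 nM in this assay, at which 2 of the 3 values shown sit.
Among the compounds shown here, the step between the two limits cannot be read, while the one readable step is an at least 1.0-fold higher number from compound 1 to compound 3 (0.02 log units; that floor lies within the scatter) and stays within the scatter at its floor. As far as these compounds go, whether an amine or a carboxylic acid on this phenyl ring would give a value clear of the limit stays open, as does the effect of a longer chain on this nitrogen.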